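Swapping a phenolic hydroxy for chloro on a chalcone-like core

The compounds below may be only part of what the source reports. "The series", "measured", "known", "first", "only" and "open" are said of these compounds alone.

Measured so far in a functional assay on T47D cells (Homo sapiens) for cytotoxicity, read by sulforhodamine B assay, with a stated time of 24 h; a higher number here means a weaker inhibitor of growth, a lower number a stronger inhibitor of growth:
Compound 1 `COc1ccc(C(=O)/C=C/c2cc3ccccc3[nH]c2=O)cc1`: compound 1 reaches only the limit > 100000 nM.
Compound 2 `O=C(/C=C/c1cc2ccccc2[nH]c1=O)c1ccc(O)cc1`: compound 2 gives 20400 nM.

Going by the values given here, compound 2 is the only compound with a numbered value in this assay; compound 1 sits at the limit (the limit of > 100000 nM in this assay, at which 1 of the 2 values shown sits). The step of an at least 4.9-fold lower number from compound 1 to compound 2 (0.69 log units; beyond the scatter) is the only measured one, and it shows that uncovering the oxygen on that ring moved the value from the limit to a number.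

Compound 3 `O=C(/C=C/c1cc2ccccc2[nH]c1=O)c1ccc(Cl)cc1` differs from compound 2 by chloro in place of hydroxy on an aromatic carbon, so the oxygen that the measured step turned out to matter is removed altogether. With compound 2 improving on compound 1 by an at least 4.9-fold lower number from compound 1 to compound 2 (0.69 log units; beyond the scatter), compound 3 is expected to drift back toward weaker inhibition, a step of about a 2.5-fold higher number from compound 2 to compound 3 (0.39 log units; beyond the scatter) in this assay. Compound 3 is therefore estimated at 50000 nM, within 15000 nM to 150000 nM.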

Compound 3, concentration for total growth inhibition: > 100000 nM
Compound 3 ended at the assay's limit; the forecaster's own chance of this, stated with the estimate: 35%; middle value at least 2.0-fold (0.30 log units) from the limit.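

In this assay, replacing the hydroxy with chloro gives an at least 4.9-fold higher number from compound 2 to compound 3 (0.69 log units; beyond the scatter), so the move from 4-hydroxyphenyl to 4-chlorophenyl loses the measurable growth inhibition, just as capping the oxygen with methyl does. Among these three compounds, only compound 2, with its free hydroxy, gives a number rather than a limit, which shows that at this position a chloro does not stand in for the hydroxy. Compound 1 and compound 3 both stop at a limit and not at a number, so the step between them cannot be read: the limit of > 100000 nM in this assay, at which 2 of the 3 values shown sit.

As far as these compounds go, how far compound 1 and compound 3 lie beyond that limit stays unknown, so they cannot be ranked against each other. Also open, from the compounds shown here alone, is whether an amine or a carboxylic acid at this position would give a number, and how it would compare with compound 2.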